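The source may hold more compounds than are shown below. What is called first, only, known or untested is meant among the compounds shown, and "the series" means these compounds.

The measured compounds:

Compound 1 `Cc1noc(NS(=O)(=O)c2cccc3c(NC(=O)C(C)C)cccc23)c1C` gives 880 nM in an assay on VSM-A10 cells for antagonist activity at Endothelin-1 receptor (Rattus norvegicus); on this read-out lower numbers stand for stronger inhibition and higher numbers for weaker inhibition.
Compound 2 `Cc1noc(NS(=O)(=O)c2ccc(NC(=O)Nc3ccccc3)cc2)c1C` gives 38000 nM in this assay.
Compound 3 `CC(C)(C)c1cc(NS(=O)(=O)c2ccc(N)cc2)no1` reaches only a limit of this assay, > 32000 nM.

Among these, compound 1 stands lowest of the two numbers actually measured; compound 2 is its nearest neighbour and sits well beyond the usual scatter above it. The result for compound 3 is a limit and not a number (the limit of > 32000 nM in this assay, at which 1 of the 3 values shown sits).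

Compound 4 `Cc1noc(NS(=O)(=O)c2cccc3c(NCc4ccccc4)cccc23)c1C` keeps the core of compound 1 and differs from it in one place: benzyl in place of isopropylcarbonyl on a nitrogen on an aromatic ring. The shared nitrogen thus carries a benzyl group instead of an isopropylcarbonyl group, so the change from (isopropylcarbonyl)amino to benzylamino is the whole of it.

No measured pair shows this kind of exchange, so the account can only reason from compound 1 itself. The author expects the step of a 1.7-fold higher number from compound 1 to compound 4 (0.23 log units; within the scatter) to be small, within or just beyond the scatter, and leaning toward a weaker result. For compound 4 the estimate is therefore 1500 nM, with a range from 300 nM to 8000 nM.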

Compound 4, half-maximal inhibitory concentration: 590 nM
For compound 4 the middle estimate is 2.5-fold (0.41 log units) above the measured one; the measured number falls inside the stated range.
By their numbers in this assay, from the lowest: compounds 4 and 1 (each within the scatter of the next); then compound 2.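

Putting benzyl in place of isopropylcarbonyl on a nitrogen on an aromatic ring gives a 1.5-fold lower number from compound 1 to compound 4 (0.17 log units; within the scatter) in this assay. Among these compounds, this is the first exchange at this place that can be read, and it shows that the carbonyl of compound 1 is not required for compound 4 to lie within the scatter of it, even with a six-membered aromatic ring of carbon only entering at the same nitrogen. Nothing shown here bears on what lies behind this result.

Going by these compounds, it remains open whether a free amine, a methyl group or a longer alkyl chain on this nitrogen would read like these two groups, and whether a carboxylic acid on the benzyl ring would be accepted. On these data alone, whether the same exchange reads alike on another core is also open.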